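The compounds below may be only part of what the source reports. "The series", "measured", "known", "first", "only" and "open" are said of these compounds alone.

In an ADME assay on Vero cells (Chlorocebus sabaeus) for cytotoxicity, read by MTT assay, with a stated time of 72 h (on this read-out lower numbers stand for higher toxicity in this test and higher numbers for lower toxicity in this test), three compounds sharing a core have been measured. Compound 1 `COC(=O)CCN1CCN(c2c(F)cc3c(=O)c(C(=O)O)cn(C4CC4)c3c2OC)CC1C` gives > 1000 ug/mL, and this is a limit of the assay, not a number. Compound 2 `COc1c(N2CCN(CC(C)=O)C(C)C2)c(F)cc2c(=O)c(C(=O)O)cn(C3CC3)c12` gives 500 ug/mL. Compound 3 `COc1c(N2CCN(C/C(C)=N/NC(C)=O)C(C)C2)c(F)cc2c(=O)c(C(=O)O)cn(C3CC3)c12` gives 707 ug/mL. Compound 3 cannot be told apart from compound 2 on these numbers, since the measured step is a 1.4-fold higher number from compound 2 to compound 3 (0.15 log units; within the scatter).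

The next structure is compound 4 `COc1c(N2CCN(C/C(C)=N/O)C(C)C2)c(F)cc2c(=O)c(C(=O)O)cn(C3CC3)c12`, still unmeasured in this assay. Its change is hydroxy in place of acetamido on a double-bonded nitrogen. Among the compounds with values here, no measured step makes this exact exchange, so the evidence is indirect. The closest comparison is the change of side chain that produced compound 3 from compound 2, a 1.4-fold higher number from compound 2 to compound 3 (0.15 log units; within the scatter), which is small even though that exchange alters the group substantially. The steps from the limit of compound 1 are an at least 2.0-fold lower number from compound 1 to compound 2 (0.30 log units; that floor lies within the scatter) and an at least 1.4-fold lower number from compound 1 to compound 3 (0.15 log units; that floor lies within the scatter), and they give only floors that remain within the scatter.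

Taken together, these steps suggest no expected shift beyond the scatter in either direction. The estimated step is a 1.2-fold lower number from compound 3 to compound 4 (0.07 log units; within the scatter). For compound 4 the expected value is 600 ug/mL, with an estimated range from 300 ug/mL to 1200 ug/mL.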

Compound 4, half-maximal cytotoxic concentration: 177 ug/mL
Estimate against measurement, compound 4: 3.4-fold (0.53 log units) above; measured number below the stated range.
By their numbers in this assay, from the lowest: compound 4; then compounds 2 and 3 (each within the scatter of the next). At a limit, above all of these: compound 1.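

In this assay, hydroxy in place of acetamido on a double-bonded nitrogen gives the first step among these side chains that clearly exceeds the scatter, a 4.0-fold lower number from compound 3 to compound 4 (0.60 log units; beyond the scatter), whereas compounds 2 and 3 could not be told apart. The side chain of compound 4 also separates from the one ending in acetyl, with a 2.8-fold lower number from compound 2 to compound 4 (0.45 log units; beyond the scatter), so this position does respond to the group carried on that nitrogen and compound 4 now holds the lowest number of the series. The step of an at least 5.6-fold lower number from compound 1 to compound 4 (0.75 log units; beyond the scatter) is also beyond the scatter, but it gives only a floor and not a full size, as compound 1 stands at a limit: the limit of > 1000 ug/mL in this assay, at which 1 of the 4 values shown sits.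

The compounds shown do not tell whether the lower number is specific to hydroxy or would also appear with a methoxy group or an amine on that double-bonded nitrogen. They also leave open whether a longer chain on the oxygen would bring the number back towards that of compound 3, and how far the number of compound 1 lies past its limit.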